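This account rests on a few compounds, and the source may have more. Where it says the series, first, only, none or still open, it means among the compounds named here.

Compounds measured so far in a functional assay on a cell-free system (plasma, Oryctolagus cuniculus) for inhibition, with stated times of 5 min, 1 min and 6 min; a higher number here means a weaker inhibitor, a lower number a stronger inhibitor:

Compound 1, `CCOC(=O)c1c(C)nc(-c2ccccc2)n1OC`, reaches only the limit of > 30000 nM.
Compound 2, `CCOC(=O)c1c(C)nc(-c2cccc(C#N)c2)n1OCc1ccncc1`, gives 6200 nM.
Compound 3, `CCOC(=O)c1c(C)nc(-c2cccc(C#N)c2)n1OCc1ccc(C(=O)OC)cc1`, gives 9470 nM.

Compound 2 holds the lowest of the two numbers. Its nearest neighbour is compound 3, and the step of a 1.5-fold higher number from compound 2 to compound 3 (0.18 log units; within the scatter) stays within the scatter, so the two cannot be ordered. Compound 1 sits at the limit of > 30000 nM in this assay, at which 1 of the 3 values shown sits, a limit rather than a number, and tells nothing about the size of its own inhibition.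

The next compound, compound 4, `CCOC(=O)c1c(C)nc(-c2cccc(C#N)c2)n1OCc1cccc(C#N)c1`, differs from compound 2 at one place: 3-cyanophenyl in place of pyridin-4-yl on a saturated chain carbon bound to an oxygen on an aromatic ring. Cut one bond further out, the change reads (pyridin-4-yl)methyl to 3-cyanobenzyl. Within the data shown here, the only measured step that touches this same position is a 1.5-fold higher number from compound 2 to compound 3 (0.18 log units; within the scatter), where a different six-membered ring replaced the pyridin-4-yl and the number moved within the scatter. On that basis the expected step is a 1.1-fold higher number from compound 2 to compound 4 (0.05 log units; within the scatter), nothing beyond the scatter in either direction. In this assay compound 4 is therefore estimated at 7000 nM, with a range from 3000 nM to 16000 nM.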

Compound 4, half-maximal inhibitory concentration: > 30000 nM
Compound 4: no number, only a limit; the forecaster's own chance of this, stated with the estimate: 5%; middle value at least 4.2-fold (0.63 log units) away from the limit.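

In this assay compound 4 gives > 30000 nM and this is a limit, not a number: the limit of > 30000 nM in this assay, at which 2 of the 4 values shown sit. The change of group gives an at least 4.8-fold higher number from compound 2 to compound 4 (0.68 log units; beyond the scatter) and, against the other ring, an at least 3.1-fold higher number from compound 3 to compound 4 (0.50 log units; beyond the scatter), so the group on a saturated chain carbon bound to an oxygen on an aromatic ring does matter, which the earlier step at this position, within the scatter, had not shown. All three groups here are six-membered aromatic rings, so a ring of that size does not by itself keep the number near those of compound 2 and compound 3, and how large the loss really is cannot be told from a limit.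

The compounds shown do not separate the nitrile on the 3-cyanophenyl ring from the benzyl ring that carries it, and a plain unsubstituted benzyl at this position would be the direct test. As far as these compounds go, it also stays open whether any group here can bring the number below that of compound 2, for instance a benzyl bearing an amine or a carboxylic acid.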